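A few compounds are considered here, and "the series" means these few. Any claim that something is new, unique, unknown or untested is made for them only; others in the source may bear on it.

Measured compounds:
compound 1, `CN(C)CC[C@H](CSc1ccccc1)Nc1ccc(S(=O)(=O)NC(=O)c2ccc(N3CCC(=Cc4ccccc4Cl)CC3)cc2)cc1[N+](=O)[O-]`, 0.7 nM
compound 2, `COc1ccccc1C=C1CCN(c2ccc(C(=O)NS(=O)(=O)c3ccc(N[C@H](CCN(C)C)CSc4ccccc4)c([N+](=O)[O-])c3)cc2)CC1`, 2 nM

In an assay on isolated protein for displacement of a labelled ligand from Apoptosis regulator Bcl-2 (Homo sapiens), read by fluorescence polarization (on this read-out lower numbers stand for stronger inhibition and higher numbers for weaker inhibition), compound 2 stands with the higher of the two numbers; the step of a 2.9-fold higher number from compound 1 to compound 2 (0.46 log units; beyond the scatter) sets it apart from compound 1. Compound 3, `CN(C)CC[C@H](CSc1ccccc1)Nc1ccc(S(=O)(=O)NC(=O)c2ccc(N3CCC(=Cc4ccccc4C#N)CC3)cc2)cc1[N+](=O)[O-]`, differs from compound 2 by cyano in place of methoxy on an aromatic carbon. Among the measured compounds shown here, only one measured step touches this position, a 2.9-fold higher number from compound 1 to compound 2 (0.46 log units; beyond the scatter), in which the group on that aromatic carbon was exchanged, and it was modest. The move to cyano is a change of the same kind at the same place, and no second measurement shows which way a third group turns the number. Compound 3 is therefore expected to stay close to compound 2, with a step of a 1.3-fold lower number from compound 2 to compound 3 (0.12 log units; within the scatter) that need not go beyond the scatter. The estimate for compound 3 in this assay is 1.5 nM, with a range from 0.5 nM to 5 nM.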

Compound 3, inhibition constant: 13 nM
Beside the measured number, compound 3's estimate is 8.7-fold (0.94 log units) below it; measured number outside the range, above it.
By their numbers in this assay, from the lowest: compound 1; then compound 2; then compound 3.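

In this assay, among the compounds shown here, the group on this aromatic carbon turns out to matter more than the single earlier exchange showed: cyano gives a 6.5-fold higher number from compound 2 to compound 3 (0.81 log units; beyond the scatter), and measured against chloro the change is larger still, a 19-fold higher number from compound 1 to compound 3 (1.27 log units; beyond the scatter). Methoxy and cyano have the same count of heavy atoms and of hydrogen-bond acceptors, yet their numbers lie apart beyond the scatter, so these counts alone do not set the number at this position. Nothing available explains why cyano gives the highest number of the three.

On these data alone, it remains open where a methyl, a fluoro or an amine on this same aromatic carbon would fall relative to chloro, methoxy and cyano. As far as these compounds go, it is also open whether the same order would hold on a core changed elsewhere.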